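A few compounds are considered here, and "the series" means these few. Any claim that something is new, unique, unknown or untested is made for them only; others in the source may bear on it.

Compound 1 `OC[C@H]1O[C@@H](n2cnc3c(NCc4cccc(F)c4)ncnc32)[C@H](O)[C@@H]1O` was examined in an ADME assay on NIH3T3 cells (Mus musculus) for cytotoxicity, with a stated time of 72 h (on this read-out higher numbers stand for weaker inhibition and lower numbers for stronger inhibition), and in that assay compound 1 gives 84000 nM, a weak effect on the cells. Among the compounds described here it is the only one with a number: for compound 2 `COc1ccc(CNc2ncnc3c2ncn3[C@@H]2O[C@H](CO)[C@@H](O)[C@H]2O)c(OC)c1` the outcome in this assay is recorded as "not determined" (no result reported), so no comparison can be drawn from it. Compound 3 `OC[C@H]1O[C@@H](n2cnc3c(NCc4ccc(F)c(Cl)c4)ncnc32)[C@H](O)[C@@H]1O` has not yet been tested. It differs from compound 1 only at the position described by 3-chloro-4-fluorophenyl in place of 3-fluorophenyl on a saturated chain carbon bound to a nitrogen on an aromatic ring. For the measured compounds named here, no measured pair of this kind is available, so any expectation for compound 3 rests on compound 1 alone. The step of a 1.4-fold lower number from compound 1 to compound 3 (0.15 log units; within the scatter) is expected to be small and, if anything, toward a somewhat lower number, but not clearly beyond the scatter of repeated runs. In this assay compound 3 is therefore estimated at 60000 nM, with a likely range from 20000 nM to 150000 nM.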

Compound 3, half-maximal inhibitory concentration: > 166000 nM
Compound 3 was reported as a limit (the forecaster's own chance of this, stated with the estimate: 25%); middle value at least 2.7-fold (0.44 log units) from the limit.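

In this assay, for the compounds shown here, the change to 3-chloro-4-fluorophenyl in place of 3-fluorophenyl on a saturated chain carbon bound to a nitrogen on an aromatic ring gives an at least 1.9-fold higher number from compound 1 to compound 3 (0.29 log units; that floor lies within the scatter) and thus provides the first readable step at this position. That floor shows that the added chlorine brings no lower number here, but it does not establish a true rise. For compound 3 the reading is a limit and not a number: the limit of > 166000 nM in this assay, at which 1 of the 3 values shown sits.

From the compounds shown here alone, how much of the step belongs to the chlorine alone remains open. Also open, going by these compounds, is how this assay would respond to an amine or a carboxylic acid on the phenyl ring, or to a longer chain in place of the single carbon joining that ring to the nitrogen.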